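Anilino Swap on a Shared Core: Compound 2 to Compound 3

The source may hold more compounds than are shown below. What is called first, only, known or untested is meant among the compounds shown, and "the series" means these compounds.

Measured compounds:
compound 1, `O=C1C(Nc2cccc(Cl)c2)=CC(=O)c2c1nc1n2[C@H]2OC[C@@H](O)[C@H]2OC1`, 3080 nM
compound 2, `CCc1ccc(NC2=CC(=O)c3nc4n(c3C2=O)[C@H]2OC[C@@H](O)[C@H]2OC4)cc1`, 3080 nM

In a functional assay on ECa-109 cells for inhibition, with ECa-109 cell line (Homo sapiens) as the target, read by sulforhodamine B assay (a lower number here means a stronger inhibitor, a higher number a weaker inhibitor), compound 1 gives 3080 nM. In this assay compound 2 gives 3080 nM, level with compound 1 at the digits shown and within the scatter, so the two anilino groups on the shared core cannot be told apart on these numbers. Compound 3, `O=C1C=C(Nc2ccccc2F)C(=O)c2c1nc1n2[C@H]2OC[C@@H](O)[C@H]2OC1`, has not yet been measured in this assay. It differs from compound 2 in one place: 2-fluorophenyl in place of 4-ethylphenyl on an amine nitrogen. Among the compounds with values here, with only two measured compounds, and those two level, there is no measured step to lean on; the data give no sign that the anilino group moves this read-out. The step from compound 2 to compound 3 is expected to be small, a 1.0-fold higher number from compound 2 to compound 3 (0.00 log units; within the scatter), not beyond the scatter in either direction. For compound 3 the value in this assay is estimated at 3100 nM, ranging from 1200 nM to 8000 nM.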

Compound 3, half-maximal inhibitory concentration: 2760 nM
Compound 3: the middle estimate sits 1.1-fold (0.05 log units) above what was measured, and the stated range covers the measured number.
By their numbers in this assay, from the lowest: compounds 3, 1 and 2 (each within the scatter of the next).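

In this assay, putting 2-fluorophenyl in place of 4-ethylphenyl on the amine nitrogen gives a 1.1-fold lower number from compound 2 to compound 3 (0.05 log units; within the scatter). Within the data shown here, this is the first measured one-place step at this nitrogen, and it shows that two phenyl groups with different substituents, carried at different ring positions, are not told apart by this read-out on the shared core. No other measurement is available that bears on this result.

The compounds shown all carry a substituted phenyl group on this nitrogen, so they leave open whether a carboxylic acid or an amine on that phenyl ring, or a plain alkyl chain in place of the ring, would shift the number beyond the scatter. A single step also cannot say whether the level seen here would hold for other substituents.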